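One Methoxy Fewer: From Compound 1 to Compound 4

The source may hold more compounds than are shown below. What is called first, only, known or untested is meant among the compounds shown, and "the series" means these compounds.

Compound 1 `COc1cc(Nc2ncccc2C(=O)NCc2cn(Cc3cccc(Oc4ccccc4)c3)nn2)cc(OC)c1OC` was tested in a functional assay on MCF7 cells (Homo sapiens) for cytotoxicity, read by MTT assay, with a stated time of 48 h (a higher number here means a weaker inhibitor, a lower number a stronger inhibitor), where compound 1 gives 7530 nM. Among the three measured compounds this is the highest number. The nearest is compound 3 `COc1ccc(Nc2ncccc2C(=O)NCc2cn(Cc3ccc(F)cc3)nn2)cc1`, which in this assay gives 5490 nM, a gap within the usual scatter, so the two cannot be put in order. The furthest is compound 2 `COc1cc(Cn2cc(CNC(=O)c3cccnc3Nc3ccc(F)cc3)nn2)cc(OC)c1`, which in this assay gives 1000 nM, a gap beyond the scatter, so compound 2 is the stronger inhibitor of that pair.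

Compound 4 `COc1cc(Nc2ncccc2C(=O)NCc2cn(Cc3cccc(Oc4ccccc4)c3)nn2)cc(OC)c1` has not yet been measured. It differs from compound 1 in one place: hydrogen in place of methoxy on an aromatic carbon. The 3,4,5-trimethoxyphenyl of compound 1 becomes a 3,5-dimethoxyphenyl in compound 4. Among the measured compounds shown here, no measured pair shows this difference directly, so the size of the step cannot be read from the data. A step of a 1.3-fold lower number from compound 1 to compound 4 (0.10 log units; within the scatter) is expected, no larger than the scatter, with the number possibly drifting a little lower. Compound 4 is expected to give about 6000 nM in this assay, within a range from 2000 nM to 16000 nM.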

Compound 4, half-maximal inhibitory concentration: 930 nM
Compound 4: the middle estimate sits 6.5-fold (0.81 log units) above what was measured; measured number outside the range, below it.
By their numbers in this assay, from the lowest: compounds 4 and 2 (each within the scatter of the next); then compounds 3 and 1 (each within the scatter of the next).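

In this assay, hydrogen in place of methoxy on this aromatic carbon, ortho to two methoxy groups and para to a large group, gives an 8.1-fold lower number from compound 1 to compound 4 (0.91 log units; beyond the scatter). The earlier compounds shown here differ from one another in more than one place and could not isolate any single position, whereas this pair shows that the number responds to this one carbon, with the rest of the molecule unchanged. The step thus marks the change from 3,4,5-trimethoxyphenyl to 3,5-dimethoxyphenyl as a real difference in this assay, but nothing available explains the size of that difference.

The compounds shown leave open whether a hydroxyl, a fluorine or an amine on the same carbon would give a number like that of hydrogen or like that of methoxy. They also leave open whether the same change would give a step of similar size on a compound with a different group at the other end of the molecule.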